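A few compounds are considered here, and "the series" means these few. Any claim that something is new, unique, unknown or untested is made for them only; others in the source may bear on it.

In a functional assay on U-87MG ATCC cells for cytotoxicity against U-87 MG (Homo sapiens), read by MTT assay, with a stated time of 48 h (on this read-out lower numbers stand for stronger inhibition and higher numbers for weaker inhibition), compound 1 (`CCOC(=O)C[n+]1cccc2cc(O)ccc21`) gives > 200000 nM as a limit of the assay and not a number. Compound 2 (`C[n+]1cccc(OP(=O)([O-])OC[C@H]2O[C@@H](n3cc(F)c(=O)[nH]c3=O)C[C@@H]2OC(=O)c2ccccc2)c1`) reads 590 nM in this assay and so holds the only actual number shown so far. Compound 3 (`CCCCCCCCCC[n+]1cccc(OP(=O)([O-])OC[C@H]2O[C@@H](n3cc(F)c(=O)[nH]c3=O)C[C@@H]2OC(=O)c2ccccc2)c1`) has not yet been measured there. It differs from compound 2 by nonyl in place of hydrogen on a saturated chain carbon bound to an aromatic nitrogen in one place: nonyl in place of hydrogen on a saturated chain carbon bound to an aromatic nitrogen, so that methyl becomes decyl. In this assay, for the measured compounds named here, no measured pair yet shows what such a change does, so the expectation starts from compound 2 at 590 nM alone and leans toward stronger inhibition. The expected move is a 2.0-fold lower number from compound 2 to compound 3 (0.29 log units; within the scatter) and is only modest, not far beyond the usual scatter. For compound 3 the estimate is 300 nM with an expected range of 60 nM to 1500 nM once measured.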

Compound 3, half-maximal inhibitory concentration: 670 nM
The estimate for compound 3 lay 2.2-fold (0.35 log units) below the measured number; low and high end bracket the measured number.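

For the compounds shown here, the pair gives the first reading of this position in this assay: nonyl in place of hydrogen on a saturated chain carbon bound to an aromatic nitrogen, so that methyl becomes decyl, comes with a 1.1-fold higher number from compound 2 to compound 3 (0.06 log units; within the scatter). The position thus accepts the full nonyl extension, and in this assay the methyl and decyl forms cannot be told apart. No measured value shown bears on why the two compounds read alike. What the compounds shown leave open is whether a chain of intermediate length, such as butyl or hexyl, would also read like them. On these data alone, it is equally open whether a chain ending in an amine or a carboxylic acid at this same place would read differently.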